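Aryl swap on the dienone chain: pyridyl in place of tolyl

This account rests on a few compounds, and the source may have more. Where it says the series, first, only, none or still open, it means among the compounds named here.

Compound 1 `CC1=C(/C=C/C(=O)/C=C/c2ccc(Br)cc2)C(C)(C)CCC1` and compound 2 `CC1=C(/C=C/C(=O)/C=C/c2ccccc2C)C(C)(C)CCC1` share the same core and differ only in the aryl group on a double-bonded chain carbon bound to a double-bonded chain carbon. In a functional assay on MCF7 cells (Homo sapiens) for cytotoxicity, read by sulforhodamine B assay, with a stated time of 48 h (on this read-out higher numbers stand for weaker inhibition and lower numbers for stronger inhibition), compound 1 gives 20100 nM and compound 2 gives 44600 nM. Among the measured compounds shown here, the single step recorded, a 2.2-fold higher number from compound 1 to compound 2 (0.35 log units; beyond the scatter), leaves compound 2 as the higher of the two numbers, with compound 1 as its nearest neighbour.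

Compound 3 `CC1=C(/C=C/C(=O)/C=C/c2cccnc2)C(C)(C)CCC1` carries the change (pyridin-3-yl in place of 2-methylphenyl on a double-bonded chain carbon bound to a double-bonded chain carbon). For the measured compounds named here, no measured step involves a pyridine, so the step from compound 1 to compound 2 bears on it only as a guide to how far an aryl swap at this position has moved the number: modestly, though beyond the scatter. Going by the values given here, with no precedent for a ring nitrogen, the direction is open, and a number somewhere between the two measured values is the plainest expectation. In this assay the expected step is a 1.5-fold lower number from compound 2 to compound 3 (0.17 log units; within the scatter), not clearly beyond the scatter. Compound 3 is estimated at 30000 nM, with a range from 10000 nM to 90000 nM.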

Compound 3, half-maximal inhibitory concentration: 15500 nM
Compound 3: middle estimate off by 1.9-fold (0.29 log units), on the high side; measured number inside the range.
By their numbers in this assay, from the lowest: compounds 3 and 1 (each within the scatter of the next); then compound 2.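

Notes on the aryl position: in this assay, a ring carrying a hetero atom is accepted on a double-bonded chain carbon bound to a double-bonded chain carbon, and pyridin-3-yl in place of 2-methylphenyl gives a change beyond the scatter (a 2.9-fold lower number from compound 2 to compound 3 (0.46 log units; beyond the scatter)). The swap of 4-bromophenyl for pyridin-3-yl stays within the scatter (a 1.3-fold lower number from compound 1 to compound 3 (0.11 log units; within the scatter)), so two quite different rings give matching numbers, and among the three compounds only compound 2, with 2-methylphenyl, stands apart from the others. Nothing available accounts for this grouping or says what the ring nitrogen contributes.

Three compounds cannot separate a gain from the ring nitrogen from a penalty tied to 2-methylphenyl, and a plain phenyl group on the same chain carbon would be the direct comparison for both. As far as these compounds go, it also stays open whether the result belongs to pyridin-3-yl specifically or extends to pyridin-2-yl or pyridin-4-yl, and how a ring bearing an amine or a carboxylic acid would read in this assay on the shared core.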